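Amide substituent variation ahead of compound 4

A few compounds are considered here, and "the series" means these few. Any claim that something is new, unique, unknown or untested is made for them only; others in the source may bear on it.

The series shares one core, carried by compound 1 `O=C(Cn1cc(CN2C(=O)C(=O)c3c(Cl)ccc(Cl)c32)nn1)NC1CCCCC1`, compound 2 `O=C1C(=O)N(Cc2cn(CC(=O)N3CCNCC3)nn2)c2c(Cl)ccc(Cl)c21` and compound 3 `O=C1C(=O)N(Cc2cn(CC(=O)N3CCCCC3)nn2)c2c(Cl)ccc(Cl)c21`; the members differ only in the group on the carbonyl carbon of the side chain. In a functional assay on TE-1 cells (Homo sapiens) for inhibition, read by CCK-8 assay, with a stated time of 72 h (on this read-out lower numbers stand for stronger inhibition and higher numbers for weaker inhibition), compound 1 gives 25200 nM and compound 3 gives 40600 nM. Compound 2 returned no number in this assay, "nd(insoluble)" (no result reported). Compound 3 holds the higher of the two numbers, yet the step of a 1.6-fold higher number from compound 1 to compound 3 (0.21 log units; within the scatter) lies within the scatter, so compound 1 and compound 3 are not separated.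

Compound 4 `O=C(Cn1cc(CN2C(=O)C(=O)c3c(Cl)ccc(Cl)c32)nn1)Nc1ccccc1` is the next member: anilino in place of piperidin-1-yl on a carbonyl carbon. Within the data shown here, the one measured step that bears on this change is a 1.6-fold higher number from compound 1 to compound 3 (0.21 log units; within the scatter), a swap at the same carbonyl carbon that did not move the number beyond the scatter. No aromatic group at this position has been measured, so the range must stay wide. Compound 4 is expected to show a step of a 1.3-fold lower number from compound 3 to compound 4 (0.10 log units; within the scatter) in this assay, none beyond the scatter. Compound 4 is estimated at 32000 nM, with a range from 10000 nM to 100000 nM.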

Compound 4, half-maximal inhibitory concentration: 30600 nM
Estimate against measurement, compound 4: 1.0-fold (0.02 log units) above; the measured number falls inside the stated range.
By their numbers in this assay, from the lowest: compounds 1, 4 and 3 (each within the scatter of the next).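

In this assay, among these compounds, the first aromatic group at this carbonyl carbon leaves the number within the scatter, both for anilino in place of piperidin-1-yl (a 1.3-fold lower number from compound 3 to compound 4 (0.12 log units; within the scatter)) and for phenyl in place of cyclohexyl on the amide-type nitrogen (a 1.2-fold higher number from compound 1 to compound 4 (0.08 log units; within the scatter)). Compounds 1, 3 and 4 therefore stay unseparated across a saturated or aromatic six-membered ring, and with or without the amide hydrogen, so none of these changes at this position has yet moved the number beyond the scatter. No measurement at hand offers an explanation for this flat result.

Open, going by these compounds, is whether a phenyl ring carrying a carboxylic acid or an amine, or a benzyl group or longer chain on the amide nitrogen, would shift the number beyond the scatter. The group of compound 2 also stays outside the comparison, as that compound has no number.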